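Acetyl on the amine nitrogen of compound 3

The source may hold more compounds than are shown below. What is called first, only, known or untested is meant among the compounds shown, and "the series" means these compounds.

Values measured in a functional assay on HEp-2 cells (Homo sapiens) for cytotoxicity, read by MTT assay, with a stated time of 24 h (a lower number here means a stronger inhibitor, a higher number a weaker inhibitor), are as follows
- compound 1 `COc1cc(C)cc2c1C(=O)C=C(c1c(C)cc3c(c1OC)C(=O)C(NCc1ccccc1)=CC3=O)C2=O` gives 2610 nM
- compound 2 `CCOC(=O)CNC1=CC(=O)c2cc(C)c(C3=CC(=O)c4c(OC)cc(C)cc4C3=O)c(OC)c2C1=O` gives 860 nM
- compound 3 `COc1cc(C)cc2c1C(=O)C=C(c1c(C)cc3c(c1OC)C(=O)C(N)=CC3=O)C2=O` gives 3510 nM

Compound 3 lies with compound 1 at the high end of these three numbers, and compound 2 stands apart from both. The change to compound 4 `COc1cc(C)cc2c1C(=O)C=C(c1c(C)cc3c(c1OC)C(=O)C(NC(C)=O)=CC3=O)C2=O` is acetyl in place of hydrogen on an amine nitrogen, amino to acetamido (acetyl in place of hydrogen on an amine nitrogen). Among the compounds with values here, two measured steps concern this same nitrogen. Compound 1, with benzyl, shows no step beyond the scatter (a 1.3-fold higher number from compound 1 to compound 3 (0.13 log units; within the scatter)). Compound 2, with (ethoxycarbonyl)methyl, shows a modest one (a 4.1-fold higher number from compound 2 to compound 3 (0.61 log units; beyond the scatter)). Acetyl itself has not been measured on this nitrogen, so these steps are only a loose guide. A small move to a lower number is therefore expected in this assay, possibly none beyond the scatter. The expected step runs as follows (a 1.8-fold lower number from compound 3 to compound 4 (0.24 log units; within the scatter)). Compound 4 is estimated at 2000 nM (expected range 800 nM to 4500 nM).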

Compound 4, half-maximal inhibitory concentration: 920 nM
For compound 4 the middle estimate is 2.2-fold (0.34 log units) above the measured one; the measured number falls inside the stated range.
By their numbers in this assay, from the lowest: compounds 2 and 4 (each within the scatter of the next); then compounds 1 and 3 (each within the scatter of the next).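

In this assay, putting a carbonyl group directly on the amine nitrogen gives a clear gain over the free amino group, a 3.8-fold lower number from compound 3 to compound 4 (0.58 log units; beyond the scatter), whereas benzyl on this nitrogen gave no step beyond the scatter. Acetyl and (ethoxycarbonyl)methyl cannot be separated, a 1.1-fold higher number from compound 2 to compound 4 (0.03 log units; within the scatter), while acetyl stands apart from benzyl, a 2.8-fold lower number from compound 1 to compound 4 (0.45 log units; beyond the scatter), so among these four compounds the two substituents holding a carbonyl give the lower numbers, with no compound against that pattern. No available data explain this grouping.

Going by these compounds, whether the carbonyl itself matters remains open: benzoyl, a longer acyl chain such as butanoyl, or a carboxylic acid in place of the ethyl ester would test it. The compounds shown also leave open whether the grouping holds beyond this one cell line.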